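A few compounds are considered here, and "the series" means these few. Any claim that something is new, unique, unknown or untested is made for them only; others in the source may bear on it.

Of the compounds shown here, two have been measured so far in a physicochemical assay for lipophilicity; a higher number here means a more lipophilic compound, a lower number a more polar compound. Compound 1 (`FCCCN1CCC(COc2ccc(Br)cc2)CC1`) gives 5.88, and compound 2 (`N#Cc1ccccc1CN1CCC(COc2ccc(I)cc2)CC1`) gives 4.32. Compound 2 therefore holds the lower of the two numbers, and the gap between them lies beyond the scatter. These two compounds differ in more than one place, so their gap cannot be tied to any single change. The next compound, compound 3 (`N#Cc1cccc(CN2CCC(COc3ccc(I)cc3)CC2)c1`), has the same atoms as compound 2, joined differently: 3-cyanophenyl in place of 2-cyanophenyl on a saturated chain carbon bound to an amine nitrogen in a ring. Among the measured compounds shown here, no measured pair shows a swap of this kind, so the expectation starts from compound 2 at 4.32 and from the matching counts of the two groups. No step beyond the scatter is expected in this assay, and the estimated step is a number 0.08 log units higher from compound 2 to compound 3 (within the scatter). Compound 3 is expected at 4.4, within an estimated range from 3.9 to 4.9.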

Compound 3, partition coefficient: 4.19
Compound 3: the middle estimate sits 0.21 log units above what was measured; low and high end bracket the measured number.
By their numbers in this assay, from the lowest: compounds 3 and 2 (each within the scatter of the next); then compound 1.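

In this assay, placing 3-cyanophenyl in place of 2-cyanophenyl on a saturated chain carbon bound to an amine nitrogen in a ring gives a number 0.13 log units lower from compound 2 to compound 3 (within the scatter) and so leaves the number within the scatter, even though the atoms are joined differently. Unlike the gap between compound 1 and compound 2, this step belongs to one single change, and it is the first such step in the set. Nothing available explains the size of this step.

From the compounds shown here alone, it remains open how the number would respond if a different group, such as a carboxylic acid or a primary amine, stood on that phenyl ring in place of the nitrile. Among the compounds shown here, also open is how the gap to compound 1 divides between the halogen and the group on the amine nitrogen, with no pair yet changing either alone.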